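The source may hold more compounds than are shown below. What is called first, only, known or untested is meant among the compounds shown, and "the series" means these compounds.

Measured so far in a physicochemical assay for lipophilicity, read by HPLC, in phosphate buffer, measured as octanol-water partition, at pH 7.4; on this read-out lower numbers stand for lower lipophilicity and higher numbers for higher lipophilicity:
- compound 1, `CC(=O)N[C@@H](C)C(=O)N(C)/N=N/c1ccc(Br)cc1`: 2.8
- compound 2, `CC(=O)N[C@@H](C)C(=O)N(C)/N=N/c1ccc(C(N)=O)cc1`: 0.69
- compound 3, `CC(=O)N[C@@H](C)C(=O)N(C)/N=N/c1ccc(C)cc1`: 2.45

Compound 3 stands second highest of the three numbers. Its nearest neighbour is compound 1, and the step of a number 0.35 log units lower from compound 1 to compound 3 (beyond the scatter) is beyond the scatter but modest. Its furthest is compound 2; the step of a number 1.76 log units higher from compound 2 to compound 3 (beyond the scatter) is large. The third step, a number 2.11 log units lower from compound 1 to compound 2 (beyond the scatter), is also large.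

Compound 4, `CC(=O)N[C@@H](C)C(=O)N(C)/N=N/c1ccc(C(C)=O)cc1`, is not yet measured in this assay. It differs from compound 3 by acetyl in place of methyl on an aromatic carbon. Among the compounds with values here, the step that bears on it most directly is the one from compound 2 to compound 3, where a carbonyl-bearing group stands against methyl at the same aromatic carbon and the number moves by a large amount. Acetyl, as counted, brings one acceptor and no donor, whereas carbamoyl carries both; a drop in this assay is expected for compound 4, but one smaller than the gap between compound 2 and compound 3. The step of a number 1.05 log units lower from compound 3 to compound 4 (beyond the scatter) is therefore the expected move. For compound 4 the estimate in this assay is 1.4, with a range from 1 to 1.8.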

Compound 4, partition coefficient: 1.51
Estimate against measurement, compound 4: 0.11 log units below; the range from low to high includes it.
By their numbers in this assay, from the lowest: compound 2; then compound 4; then compound 3; then compound 1.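

In this assay, within the data shown here, acetyl on this aromatic carbon, para to a large group, is the first carbonyl-bearing group without a hydrogen-bond donor, and exchanging methyl for it gives a number 0.94 log units lower from compound 3 to compound 4 (beyond the scatter). The earlier compounds shown here offered only carbamoyl as a carbonyl-bearing group here, whereas this result separates the two through the change on the carbonyl carbon itself, with methyl in place of amino giving a number 0.82 log units higher from compound 2 to compound 4 (beyond the scatter), so that compound 4 falls between compound 2 and compound 3 with a modest step to each. Against bromo the same position shows a larger move, a number 1.29 log units lower from compound 1 to compound 4 (beyond the scatter), and no measurement in hand gives a reason for any of these three steps. Still open, from the compounds shown here alone, is whether a longer chain on the carbonyl, such as propanoyl in place of acetyl, raises the number from that of compound 4 by a regular amount. Also open, going by these compounds, is where a nitrile, a carboxylic acid or an amine at this aromatic carbon would fall in the order from compound 2 to compound 1 in this assay.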